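A Propyl Group Enters Where Hydrogen Stood

This account rests on a few compounds, and the source may have more. Where it says the series, first, only, none or still open, it means among the compounds named here.

Compound 2 `C=CCn1ncc2c(C)nc(CCC)n2c1=O` is the reference point of this small set. Among the compounds with values here, in a functional assay for inhibition, with Homo sapiens as the target (a higher number here means a weaker inhibitor, a lower number a stronger inhibitor), compound 2 gives 40000 nM, and this is the only outright number among the three values recorded. Compound 1 `C=CCn1ncc2c(C)nc(CC)n2c1=O` reaches only a limit in this assay, > 48000 nM. Compound 3 `C=CCn1ncc2c(Br)nc(CCC)n2c1=O` likewise stops at a limit in this assay, > 48000 nM. The two measured steps are therefore floors: an at least 1.2-fold lower number from compound 1 to compound 2 (0.07 log units; that floor lies within the scatter) and an at least 1.2-fold higher number from compound 2 to compound 3 (0.07 log units; that floor lies within the scatter), both of which could be nothing more than scatter, a situation shaped by the limit of > 48000 nM in this assay, at which 2 of the 3 values shown sit.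

Compound 4 `C=CCn1nc(CCC)c2c(C)nc(CCC)n2c1=O` is the next compound, and it differs from compound 2 by a single change: propyl in place of hydrogen on an aromatic carbon. Within the data shown here, only the first of the measured steps bears on it at all, as it is the one step that lengthens a chain, and it was small and uncertain. Among the measured compounds shown here, no measured step adds a chain on an aromatic carbon. The expectation is therefore a step of a 1.1-fold lower number from compound 2 to compound 4 (0.06 log units; within the scatter) in this assay, not beyond the scatter. Compound 4 is expected to give 35000 nM, within 10000 nM to 48000 nM.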

Compound 4, half-maximal inhibitory concentration: 29000 nM
Beside the measured number, compound 4's estimate is 1.2-fold (0.08 log units) above it; the range from low to high includes it.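

Propyl in place of hydrogen on an aromatic carbon, next to the ring nitrogen, gives a 1.4-fold lower number from compound 2 to compound 4 (0.14 log units; within the scatter) in this assay, and this is the first step in the set with an outright number at both ends rather than a floor. The position therefore carries propyl, a group of 3 heavy atoms, while the read-out stays a number, yet that number cannot be told apart from the number of compound 2, so this change shows no measurable gain or loss of inhibition. The earlier steps could not say even this much, since each of them ends on a limit and gives only a floor: the limit of > 48000 nM in this assay, at which 2 of the 4 values shown sit.

Going by these compounds, whether an amine, a carboxylic acid or a longer chain on this same aromatic carbon would give a step beyond the scatter remains open, as does whether a methyl group there would read like propyl. Also open, on these data alone, is whether propyl at this position would leave a number in place with bromo on the other aromatic carbon, as in compound 3, or with the ethyl chain of compound 1.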